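Chloro in place of hydrogen on the aryl ring: expectation

This account rests on a few compounds, and the source may have more. Where it says the series, first, only, none or still open, it means among the compounds named here.

compound 1, `Cc1ccc(C2CN(S(=O)(=O)c3ccc4c(c3)CCC4)C(=O)N2)cc1`: 99200 nM
compound 2, `O=C1NC(c2ccccc2)CN1S(=O)(=O)c1ccc2c(c1)CCC2`: 910 nM

Among the compounds with values here, compound 2 holds the lower of the two numbers so far in a functional assay on A549 cells (Homo sapiens) for cytotoxicity; a lower number here means a stronger inhibitor, a higher number a weaker inhibitor; the gap to the other number is a 110-fold lower number from compound 1 to compound 2 (2.04 log units; beyond the scatter), a large step. Compound 3 `O=C1NC(c2ccc(Cl)cc2)CN1S(=O)(=O)c1ccc2c(c1)CCC2` is not yet measured. It differs from compound 2 by chloro in place of hydrogen on an aromatic carbon.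

Within the data shown here, the only measured step that touches this aromatic carbon is a 110-fold lower number from compound 1 to compound 2 (2.04 log units; beyond the scatter), recorded for hydrogen in place of methyl on an aromatic carbon. That step shows the number can move strongly when a group sits there, though methyl and chloro are different groups and no chloro has yet been tested in the series. Compound 3 is therefore expected to give a higher number than compound 2, with the step of an 8.8-fold higher number from compound 2 to compound 3 (0.94 log units; beyond the scatter) estimated smaller than the loss seen with methyl and with wide uncertainty. The estimate for compound 3 in this assay is 8000 nM, range 1500 nM to 60000 nM.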

Compound 3, half-maximal inhibitory concentration: 86300 nM
Estimate against measurement, compound 3: 11-fold (1.03 log units) below, outside the stated range (above it).
By their numbers in this assay, from the lowest: compound 2; then compounds 3 and 1 (each within the scatter of the next).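

Read in this assay, the phenyl to 4-chlorophenyl change is a large loss (a 95-fold higher number from compound 2 to compound 3 (1.98 log units; beyond the scatter)), so the high number at this aromatic carbon is not confined to methyl. Chloro and methyl cannot be separated here (a 1.1-fold lower number from compound 1 to compound 3 (0.06 log units; within the scatter)), and among these three compounds only compound 2, with hydrogen on this carbon, holds the low number, with no compound going against that. Nothing available accounts for why either group gives this result.

The reading covers only methyl and chloro, so a fluoro, a methoxy or an amine on this carbon could fall with compound 2 or with compounds 1 and 3. From the compounds shown here alone, whether chloro elsewhere on the same ring carries a similar loss also stays open.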